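The source may hold more compounds than are shown below. What is called first, only, known or untested is meant among the compounds shown, and "the series" means these compounds.

Measured compounds:
Compound 1 `CO/N=c1\[nH]cnc2c1[n+](C/C=C(\C)CC/C=C(\C)CC/C=C(\C)CCC=C(C)C)cn2C(C)C` gives 2450 nM in a functional assay on ACHN cells (Homo sapiens) for cytotoxicity; a higher number here means a weaker inhibitor, a lower number a stronger inhibitor.
Compound 2 `C=CCn1c[n+](C/C=C(\C)CC/C=C(\C)CC/C=C(\C)CCC=C(C)C)c2/c(=N/OC)[nH]cnc21` gives 4610 nM in this assay.

The two numbers are separated only by a 1.9-fold higher number from compound 1 to compound 2 (0.27 log units; within the scatter), which lies within the scatter, so compound 2 stands level with compound 1. Compound 3 `CO/N=c1\[nH]cnc2c1[n+](C/C=C(\C)CC/C=C(\C)CC/C=C(\C)CCC=C(C)C)cn2CCC#N` differs from compound 2 in one respect: cyanomethyl in place of vinyl on a saturated chain carbon bound to an aromatic nitrogen. For the measured compounds named here, the only measured step, changing the group on an aromatic nitrogen, was small; no measured step touches a nitrile. For compound 3 the expected step is a 1.0-fold lower number from compound 2 to compound 3 (0.01 log units; within the scatter), none beyond the scatter. The estimate for compound 3 in this assay is 4500 nM, ranging from 1800 nM to 11000 nM.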

Compound 3, half-maximal inhibitory concentration: 11400 nM
Compound 3: the middle estimate sits 2.5-fold (0.40 log units) below what was measured; measured number outside the range, above it.
By their numbers in this assay, from the lowest: compounds 1 and 2 (each within the scatter of the next); then compound 3.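

In this assay the group on the aromatic nitrogen now separates compounds beyond the scatter: 2-cyanoethyl in place of allyl gives a weaker inhibitor (a 2.5-fold higher number from compound 2 to compound 3 (0.39 log units; beyond the scatter)), and 2-cyanoethyl in place of isopropyl does the same (a 4.7-fold higher number from compound 1 to compound 3 (0.67 log units; beyond the scatter)). Isopropyl and allyl had stood level, so this position is not indifferent to what it carries, and the nitrile-bearing chain is the one that stands apart. (Nothing available here accounts for this result). From the compounds shown here alone, whether the nitrile itself or the chain carrying it sets this level stays open, as does the outcome with an amine, a carboxylic acid or a longer chain on that nitrogen.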